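The source may report more compounds than this note shows. Statements on the series, on what has been measured and on what is new or still open speak of the compounds shown alone.

Compound 3 `CC(C)(C)/N=c1\c(O)c(O)\c1=N/Cc1ccc(Cl)cc1` gives 1700 nM in a functional assay for inhibition, with Rattus norvegicus as the target (on this read-out higher numbers stand for weaker inhibition and lower numbers for stronger inhibition), the second highest of the three numbers recorded. Compound 1 `CC[C@H](C)/N=c1\c(O)c(O)\c1=N/Cc1ccc(C#N)cc1` gives 2200 nM and compound 2 `CCC(C)(C)/N=c1\c(O)c(O)\c1=N/Cc1ccc(C#N)cc1` gives 1100 nM, and both stand within the scatter of compound 3. Among the compounds with values here, the only measured step, a 2.0-fold lower number from compound 1 to compound 2 (0.30 log units; within the scatter), concerns the group on the double-bonded nitrogen and stayed within the scatter. Compound 4 `CC(C)(C)/N=c1\c(O)c(O)\c1=N/Cc1ccc(C#N)cc1` differs from compound 3 by cyano in place of chloro on an aromatic carbon. No measured step touches an exchange at this aromatic carbon, so the numbers shown give no ground for a shift beyond the scatter in this assay. Compound 4 is therefore expected to give 1500 nM, between 700 nM and 3500 nM. The step expected from this exchange is a 1.1-fold lower number from compound 3 to compound 4 (0.05 log units; within the scatter).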

Compound 4, half-maximal inhibitory concentration: 270 nM
Beside the measured number, compound 4's estimate is 5.6-fold (0.74 log units) above it; the measured number lies below the stated range.
By their numbers in this assay, from the lowest: compound 4; then compounds 2, 3 and 1 (each within the scatter of the next).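

In this assay, this aromatic carbon proves sensitive: cyano in place of chloro gives a 6.3-fold lower number from compound 3 to compound 4 (0.80 log units; beyond the scatter) with tert-butyl on the double-bonded nitrogen. With cyano fixed, the group on that nitrogen also matters, with an 8.1-fold lower number from compound 1 to compound 4 (0.91 log units; beyond the scatter) for tert-butyl in place of sec-butyl and a 4.1-fold lower number from compound 2 to compound 4 (0.61 log units; beyond the scatter) for tert-butyl against 1,1-dimethylpropyl. No evidence given here accounts for these steps. Going by these compounds, whether fluoro, methoxy or a carboxylic acid at this aromatic carbon would match cyano remains open. So does whether the cyano-for-chloro step holds with sec-butyl or 1,1-dimethylpropyl on the nitrogen.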